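From bromo to iodo: a single atom swapped

This account rests on a few compounds, and the source may have more. Where it says the series, first, only, none or still open, it means among the compounds named here.

In a functional assay on U-87MG ATCC cells for inhibition, with U-87 MG (Homo sapiens) as the target, read by sulforhodamine B assay, with a stated time of 72 h (on this read-out higher numbers stand for an effect only at larger amounts of compound and lower numbers for an effect already at smaller amounts), compound 1 `CCC(=O)Oc1cccc2ccc(/C=C/c3ccccc3[N+](=O)[O-])nc12` gives 10500 nM and compound 2 `O=C(/C=C/c1ccc([N+](=O)[O-])o1)c1ccc(Br)cc1` gives 12600 nM as its reading, so these two numbers lie within the usual scatter of each other. Compound 3 `O=C(/C=C/c1ccc([N+](=O)[O-])o1)c1ccc(I)cc1` carries one change from compound 2, namely iodo in place of bromo on an aromatic carbon in the form of iodo in place of bromo on an aromatic carbon. For the measured compounds named here, no measured pair here shows such a swap, and no shift beyond the scatter is expected in this assay for this change. The expected step is a 1.1-fold lower number from compound 2 to compound 3 (0.06 log units; within the scatter) in this estimate. Compound 3 is expected at 11000 nM with an estimated range from 4500 nM to 27000 nM as the likely span.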

Compound 3, half-maximal effective concentration: 5200 nM
For compound 3 the middle estimate is 2.1-fold (0.33 log units) above the measured one; measured number inside the range.
By their numbers in this assay, from the lowest: compound 3; then compounds 1 and 2 (each within the scatter of the next).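

In this assay, replacing bromo with iodo on this aromatic carbon gives a 2.4-fold lower number from compound 2 to compound 3 (0.38 log units; beyond the scatter), a modest step but one beyond the scatter. For the compounds shown here, this is the first sign that the read-out responds to which atom sits at this position, even when one heavy atom is exchanged for another and no hydrogen-bond donors or acceptors are added. Nothing available here explains the step.

On these data alone, whether chloro, fluoro or an amine on this same carbon would shift the number remains open. A single pair also cannot show whether the same swap would have a similar effect on another core.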